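Cytotoxicity notes on four related compounds

The compounds below may be only part of what the source reports. "The series", "measured", "known", "first", "only" and "open" are said of these compounds alone.

Compound 1 `CC1(COc2ccc(F)cc2)Cn2cc([N+](=O)[O-])nc2O1` and compound 2 `CC1(COc2ccc(C(F)(F)F)cc2)Cn2cc([N+](=O)[O-])nc2O1` share one core and differ by trifluoromethyl in place of fluoro on an aromatic carbon. In an ADME assay on MRC5 cells (Homo sapiens) for cytotoxicity, read by fluorescence, with a stated time of 72 h (a higher number here means a weaker inhibitor, a lower number a stronger inhibitor), compound 1 gives > 64000 nM, which is a limit of the assay and not a number. In this assay compound 2 gives > 64000 nM, likewise a limit. The step that the two limits leave unreadable from compound 1 to compound 2 is therefore of unreadable size.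

Compound 3 `O=[N+]([O-])c1cn2c(n1)OC(COc1ccc(-c3ccc(F)cc3)cc1)C2` rests on a different core; the difference between the two cores is not broken down here. In this assay compound 3 gives > 64000 nM, again a limit. All three measured values sit together, as the evidence the limit of > 64000 nM in this assay, at which 3 of the 3 values shown sit, records.

Compound 4 `O=[N+]([O-])c1cn2c(n1)OC(COc1ccc(-c3ccc(C(F)(F)F)cc3)cc1)C2` is not yet measured. It differs from compound 3 by trifluoromethyl in place of fluoro on an aromatic carbon, the same change as that between compound 1 and compound 2, made at a place described in the same words. Within this set the change has occurred twice, once measured and once pending, and the measured instance gave no readable step.

Compound 4 is expected to give 100000 nM in this assay. The expected range for compound 4 runs from 64000 nM to 300000 nM. The expected step that the limit leaves unreadable from compound 3 to compound 4 is thus estimated to be flat. This rests on the step that the two limits leave unreadable from compound 1 to compound 2, whose size cannot be read. It rests too on compound 3, whose value > 64000 nM is a limit. The most likely outcome is another limit rather than a number.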

Compound 4, half-maximal inhibitory concentration: > 64000 nM
Compound 4: no number, only a limit (the forecaster's own chance of this, stated with the estimate: 90%); the middle value is on the limit's open side.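

In this assay compound 4 gives > 64000 nM, a limit of the assay and not a number. No size can be read for the step from compound 3 to compound 4, so that pair adds no readable step. The compounds shown leave open whether trifluoromethyl in place of fluoro changes cytotoxicity at all, and at what concentration any of them would give a number, with all values at one limit: the limit of > 64000 nM in this assay, at which 4 of the 4 values shown sit.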